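Extending methylamino to ethylamino: what to expect

The source may report more compounds than this note shows. Statements on the series, on what has been measured and on what is new or still open speak of the compounds shown alone.

Values measured in a functional assay on HCT-8 cells (Homo sapiens) for antiproliferative activity, read by MTT assay, with a stated time of 48 h (a lower number here means a stronger inhibitor, a higher number a weaker inhibitor), are these
compound 1 `C=C(c1ccc(OC)cc1NC(=O)CO)c1ccc(OC)c2c1C=CC(C)(C)O2` gives 470 nM
compound 2 `C=C(c1ccc(OC)cc1NC(=O)CN)c1ccc(OC)c2c1C=CC(C)(C)O2` gives 520 nM
compound 3 `C=C(c1ccc(OC)cc1NC(=O)CNC)c1ccc(OC)c2c1C=CC(C)(C)O2` gives 980 nM

Compound 3 holds the highest of these three numbers. The two steps that reach it are a 2.1-fold higher number from compound 1 to compound 3 (0.32 log units; beyond the scatter) and a 1.9-fold higher number from compound 2 to compound 3 (0.28 log units; within the scatter) so it stands clearly apart from compound 1 only.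

Compound 4 `C=C(c1ccc(OC)cc1NC(=O)CNCC)c1ccc(OC)c2c1C=CC(C)(C)O2` differs from compound 3 in one place (methyl in place of hydrogen on a saturated chain carbon bound to an amine nitrogen) with methyl in place of hydrogen on a saturated chain carbon bound to an amine nitrogen, so methylamino becomes ethylamino. Within the data shown here, no measured step makes exactly this change. The closest is a 1.9-fold higher number from compound 2 to compound 3 (0.28 log units; within the scatter) which also adds a methyl, there on the amine nitrogen. The other amine step, a different change, is a 1.1-fold higher number from compound 1 to compound 2 (0.04 log units; within the scatter) and it is also small.

A slightly higher number in this assay is therefore expected, with a step that probably stays within the usual scatter. The expected step is a 1.2-fold higher number from compound 3 to compound 4 (0.09 log units; within the scatter) and no larger shift is anticipated. Compound 4 is expected near 1200 nM with an estimated range from 600 nM to 2500 nM.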

Compound 4, half-maximal inhibitory concentration: 3050 nM
The estimate for compound 4 lay 2.5-fold (0.41 log units) below the measured number, outside the stated range (above it).
By their numbers in this assay, from the lowest: compounds 1, 2 and 3 (each within the scatter of the next, the first and the last beyond it); then compound 4.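

In this assay the change from methylamino to ethylamino gives a 3.1-fold higher number from compound 3 to compound 4 (0.49 log units; beyond the scatter) and this is a clear move, whereas the methyl added on the amine nitrogen gave only a 1.9-fold higher number from compound 2 to compound 3 (0.28 log units; within the scatter) and stayed within the scatter. Among these compounds, measured against the earlier compounds, ethyl in place of hydrogen on the amine nitrogen amounts to a 5.9-fold higher number from compound 2 to compound 4 (0.77 log units; beyond the scatter) and ethylamino in place of hydroxy amounts to a 6.5-fold higher number from compound 1 to compound 4 (0.81 log units; beyond the scatter) so this chain position does respond to substitution, and compound 4 stands apart from all three earlier compounds. Nothing measured here accounts for why a single added methyl on a saturated chain carbon bound to an amine nitrogen moves the number this far.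

As far as these compounds go, whether the number keeps rising along a longer chain, as in propylamino, remains open. So does the effect of a branched isopropylamino group or of dimethylamino, which carries its second methyl on the nitrogen.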